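A few compounds are considered here, and "the series" means these few. Any claim that something is new, unique, unknown or untested is made for them only; others in the source may bear on it.

Of the compounds shown here, three sharing one core have been measured in a functional assay on DU-145 cells (Homo sapiens) for cytotoxicity, read by MTT assay; a higher number here means a weaker inhibitor, a lower number a stronger inhibitor. Compound 1 `CC(C)=CC[C@@H](OC(=O)C1CCCCO1)C1=CC(=O)c2c(O)ccc(O)c2C1=O` gives 24700 nM. Compound 2 `COCCO[C@H](CC=C(C)C)C1=CC(=O)c2c(O)ccc(O)c2C1=O` gives 43200 nM. Compound 3 `CC(C)=CC[C@@H](OC(=O)C1CCCOC1)C1=CC(=O)c2c(O)ccc(O)c2C1=O` gives 29700 nM. Within the data shown here, on these numbers compound 3 sits between the other two: a 1.2-fold higher number from compound 1 to compound 3 (0.08 log units; within the scatter) and a 1.5-fold lower number from compound 2 to compound 3 (0.16 log units; within the scatter) both fall within the scatter, so no compound here can be called stronger or weaker than another.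

Compound 4 `CCC(O)CO[C@H](CC=C(C)C)C1=CC(=O)c2c(O)ccc(O)c2C1=O` has not yet been measured. It differs from compound 3 in one place: 2-hydroxybutyl in place of (oxan-3-yl)carbonyl on an oxygen on a saturated carbon. A ring-bearing carbonyl group on an oxygen on a saturated carbon gives way to an open chain that carries one hydrogen-bond donor. Among the measured compounds shown here, two measured steps touch this kind of exchange. Trading a ring-bearing carbonyl group for an open chain gave a 1.7-fold higher number from compound 1 to compound 2 (0.24 log units; within the scatter), and the reverse trade gave a 1.5-fold lower number from compound 2 to compound 3 (0.16 log units; within the scatter). Both were within the scatter. The 2-hydroxybutyl group of compound 4 resembles the 2-methoxyethyl group of compound 2 more than it resembles either ring-bearing group. For compound 4 the expected step is therefore a 1.3-fold higher number from compound 3 to compound 4 (0.13 log units; within the scatter), nothing beyond the scatter. Compound 4 is estimated at 40000 nM, with a range from 20000 nM to 80000 nM.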

Compound 4, half-maximal inhibitory concentration: 16400 nM
For compound 4 the middle estimate is 2.4-fold (0.39 log units) above the measured one; the whole stated range lies above it.
By their numbers in this assay, from the lowest: compounds 4, 1, 3 and 2 (each within the scatter of the next, the first and the last beyond it).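

In this assay, among these compounds, the two open chains on this oxygen do not read the same: the step from 2-methoxyethyl to 2-hydroxybutyl, a 2.6-fold lower number from compound 2 to compound 4 (0.42 log units; beyond the scatter), is the first to lie beyond the scatter, though only modestly. The ring-bearing groups give a different picture, as both a 1.8-fold lower number from compound 3 to compound 4 (0.26 log units; within the scatter) and a 1.5-fold lower number from compound 1 to compound 4 (0.18 log units; within the scatter) stay within the scatter, so 2-hydroxybutyl can stand in for (oxan-3-yl)carbonyl or (oxan-2-yl)carbonyl with no change that can be told from scatter, even though it has no ring and fewer heavy atoms. Nothing measured here explains the gap between the two open chains.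

The two chains differ both in the hydroxyl group and in the ethyl branch that 2-hydroxybutyl carries, so the compounds shown leave open which of these goes with the lower number; a 2-hydroxyethyl or a 2-methoxybutyl group on this oxygen would separate the two. They also leave open how a chain ending in an amine or a carboxylic acid would read here.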